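This account rests on a few compounds, and the source may have more. Where it says the series, first, only, none or still open, it means among the compounds named here.

Among the compounds with values here, compound 2 `CC(O)CN(c1ccnc(Nc2ccc(C#N)cc2)n1)c1c(F)cc(-c2ccc(C#N)cc2)cc1F` is examined in an ADME assay on MT4 cells (Homo sapiens) for cytotoxicity, read by MTT assay, with a stated time of 5 days (a lower number here means that less compound is tolerated, a higher number that more compound is tolerated), where compound 2 gives 9800 nM, the lowest of the two numbers measured so far. Within the data shown here, its only comparator is compound 1 `N#Cc1ccc(Nc2nccc(N(CCCO)c3c(F)cc(-c4ccc(C#N)cc4)cc3F)n2)cc1`, which in this assay gives 68000 nM; the change from compound 1 to compound 2 brought a 6.9-fold lower number from compound 1 to compound 2 (0.84 log units; beyond the scatter). Compound 3 `C=CCN(c1ccnc(Nc2ccc(C#N)cc2)n1)c1c(F)cc(-c2ccc(C#N)cc2)cc1F` has not yet been measured; it differs from compound 2 in one place: vinyl in place of 1-hydroxyethyl on a saturated chain carbon bound to a nitrogen on an aromatic ring. Among the measured compounds shown here, the one measured step concerns a shift of the hydroxyl along the chain rather than its loss, so no step bears directly on this change; it shows only that a small alteration at this position can move this assay modestly. Compound 3 is therefore expected to remain near compound 2, with a 1.2-fold higher number from compound 2 to compound 3 (0.09 log units; within the scatter) as the estimated step. On that basis compound 3 is estimated at 12000 nM, within a range from 4000 nM to 40000 nM.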

Compound 3, half-maximal cytotoxic concentration: 249000 nM
Estimate against measurement, compound 3: 21-fold (1.32 log units) below; the whole stated range lies below it.
By their numbers in this assay, from the lowest: compound 2; then compound 1; then compound 3.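

In this assay this position proves far more sensitive than the shift of the hydroxyl along the chain suggested: vinyl in place of 1-hydroxyethyl gives a 25-fold higher number from compound 2 to compound 3 (1.40 log units; beyond the scatter), a large step that exceeds the earlier one. The allyl chain also stands apart from the other hydroxyl-bearing chain, with a 3.7-fold higher number from compound 1 to compound 3 (0.56 log units; beyond the scatter), so among these three compounds both chains carrying a hydroxyl give lower numbers than the allyl chain, and no compound goes against this. No evidence at hand accounts for the size of this change.

The step removes the hydroxyl and brings in a double bond at once, and the compounds shown leave open which of the two goes with the higher number. They also leave open where a saturated propyl chain, an amine or a carboxylic acid would stand at this position.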